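Tert-Butyl Ester in Place of the Cyanomethyl Amide

The compounds below may be only part of what the source reports. "The series", "measured", "known", "first", "only" and "open" are said of these compounds alone.

Compound 1, `CSc1nc(-c2cccc(F)c2)c2c(N)c(C(=O)NC(C)(C)C)sc2n1`: 1200 nM in a functional assay on HEK293 cells for agonist activity at lutropin-choriogonadotropic hormone receptor (Homo sapiens), read by cAMP accumulation; on this read-out higher numbers stand for an effect only at larger amounts of compound and lower numbers for an effect already at smaller amounts
Compound 2, `COc1cccc(-c2nc(SC)nc3sc(C(=O)NCC#N)c(N)c23)c1`: "not determined" (no result reported) in this assay
Compound 3, `COc1cccc(-c2nc(SC)nc3sc(C(=O)NC(C)(C)C)c(N)c23)c1OC`: 800 nM in this assay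

Compound 2 stands without a number in this assay; no result was obtained for it. Compound 1 and compound 3, which both carry the tert-butylcarbamoyl group, give values within the scatter of each other.

Compound 4, `COc1cccc(-c2nc(SC)nc3sc(C(=O)OC(C)(C)C)c(N)c23)c1`, differs from compound 2 as tert-butoxy in place of (cyanomethyl)amino on a carbonyl carbon. With no value for compound 2, the size of the step in this assay cannot be measured, and its direction is open; a move either way, or a limit only, would all be unsurprising.

For compound 4 the expected value in this assay is 2500 nM, estimated within 400 nM to 15000 nM.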

Compound 4, half-maximal effective concentration: 1100 nM
Beside the measured number, compound 4's estimate is 2.3-fold (0.36 log units) above it, and the stated range covers the measured number.
By their numbers in this assay, from the lowest: compounds 3, 4 and 1 (each within the scatter of the next).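

Going by these compounds alone, no step can be read from compound 4: compound 2, the only compound differing from it in one place, has no number. The compounds shown leave open how exchanging (cyanomethyl)amino for tert-butoxy on the carbonyl carbon shifts the result in this assay. No evidence here bears on this result.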